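The source may hold more compounds than are shown below. What is called first, only, known or untested is meant among the compounds shown, and "the series" means these compounds.

Three compounds have results in an ADME assay on L1210/0 cells (Mus musculus) for cytotoxicity, with a stated time of 48 h; on this read-out higher numbers stand for weaker inhibition and lower numbers for stronger inhibition. Compound 1 `COc1ccccc1-c1ncnc2c1ncn2C[C@@H]1C[C@H](O)c2ccccc21` reaches only a limit of this assay, > 200000 nM, so for it no number is known. Compound 2 `CC1(C)[C@@H](Cn2nnc3c(Cl)nc(N)nc32)CC[C@@]1(C)CO` gives 44600 nM. Compound 3 `O=c1[nH]c(=O)n([C@H]2C[C@H](O)[C@@H](CO)O2)cc1CO` gives 9180 nM, the lowest of the two numbers; its nearest neighbour is compound 2, whose number is higher by a gap that goes beyond the usual scatter. Of the three values, one sits at the limit (the limit of > 200000 nM in this assay, at which 1 of the 3 values shown sits).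

Compound 4 `CCCc1cn([C@H]2C[C@H](O)[C@@H](CO)O2)c(=O)[nH]c1=O` has not yet been measured in this assay. It differs from compound 3 in one place: ethyl in place of hydroxy on a saturated chain carbon bound to an aromatic carbon. Among the measured compounds shown here, no two measured compounds differ in just one place, so no measured step guides the expectation directly; it rests on compound 3 alone and on the change described. Compound 4 is expected to give a higher number than compound 3, meaning weaker inhibition, with a step of a 5.4-fold higher number from compound 3 to compound 4 (0.74 log units; beyond the scatter) that is expected to go beyond the scatter. The estimate for compound 4 is 50000 nM, within a range from 10000 nM to 250000 nM.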

Compound 4, half-maximal inhibitory concentration: > 200000 nM
Compound 4: no number, only a limit; the forecaster's own chance of this, stated with the estimate: 25%; middle value at least 4.0-fold (0.60 log units) from the limit.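

Putting ethyl in place of hydroxy on a saturated chain carbon bound to an aromatic carbon gives, in this assay, an at least 21-fold higher number from compound 3 to compound 4 (1.33 log units; beyond the scatter), so this one place has a large bearing on the read-out. Compound 4 gives > 200000 nM, which is a limit of the assay and not a number, so the step has a floor but no known full size. This places compound 4 with the other compound at the top of the range: the limit of > 200000 nM in this assay, at which 2 of the 4 values shown sit.

This single pair cannot separate the loss of the hydroxy from the gain of the ethyl, since the change from hydroxymethyl to propyl does both at once. It also leaves open how an amine, a carboxylic acid or a simple methyl on that same chain carbon would read out.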